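Dropping one phenyl from the nitrogen substituent of compound 1

The source may report more compounds than this note shows. Statements on the series, on what has been measured and on what is new or still open speak of the compounds shown alone.

Compound 1 `CCCc1cn(C(c2ccccc2)c2ccccc2)nn1` gives 11000 nM in an assay on isolated protein for inhibition of Aromatase (Homo sapiens), read by fluorescence and colorimetric assay, with a stated time of 30 min; a lower number here means a stronger inhibitor, a higher number a weaker inhibitor.
Compound 2 `c1ccc(C(c2ccccc2)n2cc(C3CCCCC3)nn2)cc1` gives 13700 nM in this assay.

In this assay compound 1 stands alongside compound 2, the two separated only by a 1.2-fold higher number from compound 1 to compound 2 (0.10 log units; within the scatter). Compound 3 `CCCc1cn(Cc2ccccc2)nn1` differs from compound 1 by hydrogen in place of phenyl on a saturated chain carbon bound to an aromatic carbon and an aromatic nitrogen. Going by the values given here, the only measured step, a 1.2-fold higher number from compound 1 to compound 2 (0.10 log units; within the scatter), alters the propyl group rather than the nitrogen substituent, so it does not bear on this change, and no measured pair shows the effect of removing a phenyl there. The expectation for compound 3 is therefore uncertain, with a modest weakening, a 2.3-fold higher number from compound 1 to compound 3 (0.36 log units; beyond the scatter), taken as the most likely outcome. Compound 3 is expected to give 25000 nM, within 8000 nM to 80000 nM.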

Compound 3, half-maximal inhibitory concentration: 12600 nM
Estimate against measurement, compound 3: 2.0-fold (0.30 log units) above, and the stated range covers the measured number.
By their numbers in this assay, from the lowest: compounds 1, 3 and 2 (each within the scatter of the next).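

Swapping phenyl for hydrogen on the saturated chain carbon bound to an aromatic carbon and an aromatic nitrogen gives a result in this assay that stays within the scatter (a 1.1-fold higher number from compound 1 to compound 3 (0.06 log units; within the scatter)). In this pair, then, the second phenyl at this carbon is not needed to keep the reading at the level of compound 1. No measured evidence at hand offers an explanation for this.

Still open, on these data alone, is whether an amine or a carboxylic acid at this carbon, or a longer chain in place of propyl, would shift the number.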